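The compounds below may be only part of what the source reports. "The series", "measured", "known", "first", "only" and "open" are said of these compounds alone.

Measured in a functional assay on A549 cells (Homo sapiens) for antiproliferative activity, read by MTT assay, with a stated time of 72 h; a higher number here means a weaker inhibitor, a lower number a stronger inhibitor:
- compound 1 `CNC(=O)c1cc(Oc2ccc(NC(=O)c3nn(-c4ccccc4Cl)c(=O)cc3C)cc2F)ccn1`: 11800 nM
- compound 2 `CCCNC(=O)c1cc(Oc2ccc(NC(=O)c3nn(-c4ccccc4C)c(=O)cc3C)cc2F)ccn1`: 25700 nM
- compound 3 `CCCNC(=O)c1cc(Oc2ccc(NC(=O)c3nn(-c4cccc(C(F)(F)F)c4)c(=O)cc3C)cc2F)ccn1`: 9240 nM

Compound 3, at 9240 nM, cannot be told apart from compound 1 and stands clear of compound 2. Compound 4 `CNC(=O)c1cc(Oc2ccc(NC(=O)c3nn(-c4cccc(C(F)(F)F)c4)c(=O)cc3C)cc2F)ccn1` differs from compound 3 by one change: hydrogen in place of ethyl on a saturated chain carbon bound to an amide-type nitrogen, so propylcarbamoyl becomes methylcarbamoyl. Among the measured compounds shown here, the only measured step, a 2.8-fold lower number from compound 2 to compound 3 (0.44 log units; beyond the scatter), concerns the group on the aromatic nitrogen and does not test this change. Compound 1 carries methylcarbamoyl with a different group on that nitrogen and gives 11800 nM, so no step beyond the scatter is expected in this assay. The expected step is a 1.0-fold higher number from compound 3 to compound 4 (0.01 log units; within the scatter). For compound 4 the estimated value is 9500 nM, with an expected range of 4000 nM to 22000 nM.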

Compound 4, half-maximal inhibitory concentration: 10200 nM
For compound 4 the middle estimate is 1.1-fold (0.03 log units) below the measured one; the measured number falls inside the stated range.
By their numbers in this assay, from the lowest: compounds 3, 4 and 1 (each within the scatter of the next); then compound 2.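

In this assay the change from propylcarbamoyl to methylcarbamoyl gives a 1.1-fold higher number from compound 3 to compound 4 (0.04 log units; within the scatter) with 3-(trifluoromethyl)phenyl held on the aromatic nitrogen, so removing the ethyl leaves the two compounds indistinguishable. With methylcarbamoyl held, 3-(trifluoromethyl)phenyl in place of 2-chlorophenyl gives a 1.2-fold lower number from compound 1 to compound 4 (0.06 log units; within the scatter) and these two groups cannot be told apart here. No measurement at hand accounts for either result. The compounds shown leave open whether a longer chain such as butyl, or a chain ending in an amine, would also stay level with propyl and methyl at this place.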